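Amino Substitution on the Shared Core of Compound 1

A few compounds are considered here, and "the series" means these few. Any claim that something is new, unique, unknown or untested is made for them only; others in the source may bear on it.

Among the measured compounds shown here, compound 1 `ClCc1ccc(Cn2cnc3c(Cl)ncnc32)cc1` gives the lowest of the three numbers so far in a functional assay on NCI-H322M cells (Homo sapiens) for cytotoxicity, read by sulforhodamine B assay, with a stated time of 48 h (a lower number here means a stronger inhibitor of growth, a higher number a weaker inhibitor of growth), at 4160 nM. Compound 2 `ClCc1cccc(Cn2cnc3c(Cl)nc(Cl)nc32)c1` gives 5120 nM, which lies within the scatter of compound 1. Compound 3 `Nc1nc(Cl)c2ncn(Cc3ccccc3CCl)c2n1` gives 29500 nM, beyond the scatter above compound 1. For the measured compounds named here, no single-point step between measured compounds is available. Compound 4 `Nc1nc(Cl)c2ncn(Cc3ccc(CCl)cc3)c2n1` differs from compound 1 by amino in place of hydrogen on an aromatic carbon. A weakening of growth inhibition beyond the scatter is expected, because compound 3 gives 29500 nM while also carrying an amino group on the aromatic carbon between two ring nitrogen atoms; compound 3 is, however, not a single-point analogue of compound 1. The expected step is a 3.6-fold higher number from compound 1 to compound 4 (0.56 log units; beyond the scatter). Compound 4 is expected to give 15000 nM, within 5000 nM to 45000 nM.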

Compound 4, concentration for total growth inhibition: 42700 nM
Compound 4: middle estimate off by 2.8-fold (0.45 log units), on the low side, and the stated range covers the measured number.
By their numbers in this assay, from the lowest: compounds 1 and 2 (each within the scatter of the next); then compounds 3 and 4 (each within the scatter of the next).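

Amino in place of hydrogen on the aromatic carbon between two ring nitrogen atoms gives a 10-fold higher number from compound 1 to compound 4 (1.01 log units; beyond the scatter) in this assay and is the first single-point reading at this position. On the core of compound 1, this carbon is therefore sensitive to the change, with growth inhibition clearly weaker after the amino group enters. Nothing available bears on the reason for this step.

Going by these compounds, whether a methyl, hydroxyl or dimethylamino group at this carbon would weaken growth inhibition to the same extent remains open. Also open, on these data alone, is whether the step would persist with a methoxy group in place of the chloro group.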